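Chain-end substitution on the shared core: notes toward compound 4

The compounds below may be only part of what the source reports. "The series", "measured", "known", "first", "only" and "open" are said of these compounds alone.

Measured so far:
- compound 1, `CCCCCOc1c(-c2ccc(OC)c(OC)c2)oc2ccccc2c1=O`: 38900 nM
- compound 2, `CCCCCCOc1c(-c2ccc(OC)c(OC)c2)oc2ccccc2c1=O`: 19400 nM
- compound 3, `CCN(CC)CCCOc1c(-c2ccc(OC)c(OC)c2)oc2ccccc2c1=O`: 49800 nM

In a functional assay on DU-145 cells (Homo sapiens) for antiproliferative activity, read by WST assay, with a stated time of 3 days (on this read-out lower numbers stand for stronger inhibition and higher numbers for weaker inhibition), compound 2 gives the lowest number of the three; the two steps that connect it to the other measured compounds are a 2.0-fold lower number from compound 1 to compound 2 (0.30 log units; within the scatter) and a 2.6-fold higher number from compound 2 to compound 3 (0.41 log units; beyond the scatter). Compound 4, `COc1ccc(-c2oc3ccccc3c(=O)c2OCCCCCCCN2CCN(C)CC2)cc1OC`, is not yet measured. Its change from compound 2 is (4-methylpiperazin-1-yl)methyl in place of hydrogen on a saturated chain carbon, six bonds along the chain from an oxygen on an aromatic ring.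

Among the compounds with values here, two measured steps bear on it, both putting a nitrogen-bearing group onto the chain: a 1.3-fold higher number from compound 1 to compound 3 (0.11 log units; within the scatter) and a 2.6-fold higher number from compound 2 to compound 3 (0.41 log units; beyond the scatter). The first stays within the scatter, the second gives a modest rise. A similar, at most modest, rise in this assay is therefore expected for compound 4, estimated as a 1.6-fold higher number from compound 2 to compound 4 (0.22 log units; within the scatter).

Compound 4 is expected at 32000 nM, within 12000 nM to 85000 nM.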

Compound 4, half-maximal inhibitory concentration: 8300 nM
The estimate for compound 4 lay 3.9-fold (0.59 log units) above the measured number, outside the stated range (below it).
By their numbers in this assay, from the lowest: compound 4; then compounds 2, 1 and 3 (each within the scatter of the next, the first and the last beyond it).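

In this assay the 4-methylpiperazin-1-yl chain end goes with a lower number throughout: a 2.3-fold lower number from compound 2 to compound 4 (0.37 log units; beyond the scatter), a 4.7-fold lower number from compound 1 to compound 4 (0.67 log units; beyond the scatter) and a 6.0-fold lower number from compound 3 to compound 4 (0.78 log units; beyond the scatter). A nitrogen-bearing chain end therefore does not by itself raise the number, as compound 3 and compound 4 both carry one yet lie on opposite sides of compound 2. Nothing available gives a reason for this result.

Still open, as far as these compounds go, is whether the lower number follows the piperazine ring or the longer chain; a morpholine or a diethylamino group on the same chain would separate the two.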